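The source may hold more compounds than are shown below. What is called first, only, known or untested is meant among the compounds shown, and "the series" means these compounds.

Compound 1 `CC(C)C[C@@H](C=O)NC(=O)[C@@H](NS(C)(=O)=O)C(C)C` holds the lower of the two numbers recorded: in an assay on isolated protein for inhibition of Calpain-1 catalytic subunit (Rattus norvegicus), read by fluorescence (a higher number here means a weaker inhibitor, a lower number a stronger inhibitor), compound 1 gives 830 nM, while compound 2 `CC(C)C[C@@H](C=O)NC(=O)[C@H](C(C)C)N(C)S(=O)(=O)c1ccc(F)cc1` gives 21000 nM. Compound 3 `CC(C)C[C@@H](C=O)NC(=O)[C@@H](NS(=O)(=O)c1ccc(Cl)cc1)C(C)C` is compound 1 with 4-chlorophenyl in place of methyl on a sulfonyl sulfur. Going by the values given here, no measured pair isolates this single change, and compound 2 differs from compound 1 in two places at once, so its weaker number cannot be read as the effect of the 4-chlorophenyl alone. A modest gain in potency is expected, amounting to a 1.7-fold lower number from compound 1 to compound 3 (0.22 log units; within the scatter). For compound 3 the estimate in this assay is 500 nM, within a range of 120 nM to 2500 nM.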

Compound 3, half-maximal inhibitory concentration: 31 nM
The estimate for compound 3 lay 16-fold (1.21 log units) above the measured number; the measured number lies below the stated range.
By their numbers in this assay, from the lowest: compound 3; then compound 1; then compound 2.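

In this assay, 4-chlorophenyl in place of methyl on a sulfonyl sulfur gives a 27-fold lower number from compound 1 to compound 3 (1.43 log units; beyond the scatter). Going by these compounds alone, this is the first single change that can be read at this position, and it shows that a far larger group with an aromatic ring is accepted there and lowers the number well beyond the scatter. Nothing measured here explains why the number falls. On these data alone, it remains open whether the ring alone accounts for the step or the chlorine also contributes, which a plain phenyl group could test. A longer chain such as ethyl or butyl in place of methyl is another open comparison.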